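Azido for trifluoroacetamide on the pyrrolidine carbon

The source may report more compounds than this note shows. Statements on the series, on what has been measured and on what is new or still open speak of the compounds shown alone.

Measured so far in an ADME assay on microsomes from liver (Mus musculus) for metabolic stability, read by LC-MS, with NADPH named in the record, with a stated time of 60 min, tested at 1 uM, in the absence of a further agent; a lower number here means that less of the compound is left, a higher number that more of the compound is left:
- compound 1 `CC(=O)N[C@@H]1CCN(c2cc(C)nn3c(-c4cccs4)c(C)nc23)C1` gives > 95%
- compound 2 `COc1ccc(-c2c(C)nc3c(N4CC[C@@H](NC(=O)C(F)(F)F)C4)cc(C)nn23)cc1OC` gives > 95%

Compound 2 sits at the limit of this assay: its value of > 95% is a limit, not a number. The same holds for compound 1, whose value of > 95% is also a limit. Within the data shown here, both results rest on (the limit of > 95% in this assay, at which 2 of the 2 values shown sit); no gap between the two compounds can be read from them, and no step between measured compounds is available.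

The next compound is compound 3 `COc1ccc(-c2c(C)nc3c(N4CC[C@@H](N=[N+]=[N-])C4)cc(C)nn23)cc1OC`. It differs from compound 2 by azido in place of ((trifluoromethyl)carbonyl)amino on a saturated ring carbon.

With both measured compounds at the limit of this assay, the expectation for compound 3 rests only on compound 2 giving > 95% and on compound 1 giving > 95%. The step from compound 2 to compound 3 is expected to be a number at least 3 percentage points lower from compound 2 to compound 3 (that floor lies within the scatter), that is, no change beyond the scatter, with a real chance that the result is again reported as a limit. Compound 3 is estimated at 92%, between 78% and 100%.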

Compound 3, percent of the compound remaining: > 95%
Compound 3 gave a limit, no number; the forecaster's own chance of this, stated with the estimate: 60%; middle value at least 3 percentage points from the limit.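

No step from compound 2 to compound 3 can be read, because both results, like that of compound 1, rest on one limit: the limit of > 95% in this assay, at which 3 of the 3 values shown sit.

The compounds shown leave open whether azido and ((trifluoromethyl)carbonyl)amino on this saturated ring carbon differ at all in the percent of compound remaining, and by how much.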